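A few compounds are considered here, and "the series" means these few. Any claim that something is new, unique, unknown or untested is made for them only; others in the source may bear on it.

Measured so far:
compound 1 `O=C(N[C@@H]1CNCC[C@H]1c1ccc(Cl)cc1)c1ccc(-c2ncnc3c2CCC3O)s1` — 23000 nM in a functional assay on HCT-116 cells (Homo sapiens) for antiproliferative activity, read by sulforhodamine B assay, with a stated time of 72 h; a higher number here means a weaker inhibitor, a lower number a stronger inhibitor
compound 2 `Cn1ncc(Cl)c1-c1cc(C(=O)N[C@@H]2CN[C@H](CCN3CCC(O)CC3)C[C@H]2c2ccc(Cl)c(Cl)c2)oc1Cl` — 13700 nM in this assay

Both numbers sit in the weak range of this assay. Compound 2 carries the lower of the two, but its gap to compound 1 is within the scatter, so the two compounds cannot be told apart on these numbers, and neither stands out.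

Compound 3 `Cn1ncc(Cl)c1-c1cc(C(=O)N[C@@H]2CN[C@H](CC(=O)NCCO)C[C@H]2c2ccc(Cl)c(Cl)c2)oc1Cl` has not been measured. It differs from compound 2 in one place: (2-hydroxyethyl)carbamoyl in place of (4-hydroxypiperidin-1-yl)methyl on a saturated chain carbon bound to a saturated ring carbon. For the measured compounds named here, no measured pair in the set shows a change of this kind, so nothing here fixes its size. Given the values of compound 1 and compound 2, a step of a 1.2-fold higher number from compound 2 to compound 3 (0.07 log units; within the scatter) is expected in this assay — none beyond the scatter, with the number staying in the weak range. Compound 3 is estimated at 16000 nM in this assay, with a range from 6000 nM to 45000 nM.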

Compound 3, half-maximal inhibitory concentration: 670 nM
The estimate for compound 3 lay 24-fold (1.38 log units) above the measured number, and the stated range ends above it.
By their numbers in this assay, from the lowest: compound 3; then compounds 2 and 1 (each within the scatter of the next).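

For the compounds shown here, the exchange of (4-hydroxypiperidin-1-yl)methyl for (2-hydroxyethyl)carbamoyl on a saturated chain carbon bound to a saturated ring carbon is the first single change to move the number in this assay (a 20-fold lower number from compound 2 to compound 3 (1.31 log units; beyond the scatter)). This place in the structure is therefore not indifferent to what it carries, even though the values of compound 1 and compound 2 could not be told apart. No measurement at hand accounts for the size of this step.

The change removes the ring and brings in the carbonyl and the amide hydrogen in a single step, so the contribution of each remains unresolved. As far as these compounds go, it also remains open whether a primary amide, a carboxylic acid or a longer chain ending in hydroxyl at this place would give a similar number.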